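A few compounds are considered here, and "the series" means these few. Any claim that something is new, unique, unknown or untested is made for them only; others in the source may bear on it.

Measured so far:
compound 1 `O=C(NC1CCCCC1)Oc1cccc(C2=NCCO2)c1` gives 22%
compound 2 `CC1(C)COC(c2cccc(OC(=O)NC3CCCC3)c2)=N1` gives 28%

Both numbers come from an assay on membranes from cerebellum (strain Wistar) for inhibition of Monoglyceride lipase (Rattus norvegicus), read by HPLC, tested at 100 uM; a lower number here means less inhibition, a higher number more inhibition at the concentration tested (going by the name of the read-out). In this assay compound 2 and compound 1 lie within the usual scatter of each other, so nothing separates them; compound 2 simply stands as one of two values that cannot be told apart. Compound 1 and compound 2 differ in more than one place, so their pair says little about any single change.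

Compound 3 `CC1(C)COC(c2cccc(OC(=O)NC3CCCCC3)c2)=N1` is not yet measured. It differs from compound 2 in one place: cyclohexyl in place of cyclopentyl on an amide-type nitrogen. Within the data shown here, no measured pair shows this change alone, so there is no step to lean on. Compound 1 already carries the cyclohexyl group and gives a number within the scatter of compound 2, which points to no step beyond the scatter; the expected change is no change at the digits printed from compound 2 to compound 3 (within the scatter). Compound 3 is therefore estimated at 28% in this assay, with a range from 12% to 45%.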

Compound 3, a percentage reported as inhibition, at one concentration (the size of the read-out at that concentration, not a potency): 20%
For compound 3 the middle estimate is 8 percentage points above the measured one; the measured number falls inside the stated range.
By their numbers in this assay, from the lowest: compounds 3, 1 and 2 (each within the scatter of the next).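

In this assay the change from cyclopentyl to cyclohexyl on the amide-type nitrogen can now be read alone, and it gives a number 8 percentage points lower from compound 2 to compound 3 (within the scatter), so this swap of one carbon ring for another does not separate the two compounds. The group on the aromatic carbon can now also be read alone: placing the group of 7 heavy atoms where the group of 5 heavy atoms stood gives a number 2 percentage points lower from compound 1 to compound 3 (within the scatter), so neither change moves the number beyond the scatter. Nothing at hand offers an explanation for these two steps.

The compounds shown leave open whether any group on the amide-type nitrogen can shift the inhibition beyond the scatter. A phenyl ring or a longer chain such as hexyl there, or an amine on the carbon ring, would test this.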